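A few compounds are considered here, and "the series" means these few. Any claim that something is new, unique, unknown or untested is made for them only; others in the source may bear on it.

The measured compounds:
Compound 1 `CCCCCCCC/C=C\CCCCCCCCOc1cc(O)cc(O)c1C(C)=O` sits at a limit in a functional assay on HeLa cells (Homo sapiens) for cytotoxicity, read by XTT assay, with a stated time of 72 h; a lower number here means a stronger inhibitor, a higher number a weaker inhibitor: > 100000 nM.
Compound 2 `CC(C)=CCC/C=C(\C)Cc1c(O)cc(O)c2c(=O)cc(-c3ccccc3)oc12` gives 19000 nM in this assay.
Compound 3 `CC(=O)c1c(O)c(CC=C(C)C)c(O)c(CC=C(C)C)c1O` sits at a limit in this assay: > 100000 nM.

Compound 3 thus stands at the limit of the assay rather than at a number, the place described by the limit of > 100000 nM in this assay, at which 2 of the 3 values shown sit, which it shares with compound 1; only compound 2 returned a measured number. Compound 4 `CC(=O)c1c(O)cc(O)c(CC=C(C)C)c1O` differs from compound 3 in one place: hydrogen in place of 3-methylbut-2-en-1-yl on an aromatic carbon. Among the compounds with values here, no step between two measured compounds shows what this change does here. The expectation is that compound 4 remains at or beyond the limit, with a step that the limit leaves unreadable from compound 3 to compound 4 that is expected not to exceed the usual scatter. Compound 4 is therefore estimated at 150000 nM in this assay, with a range from 50000 nM to 500000 nM.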

Compound 4, half-maximal inhibitory concentration: 30000 nM
Estimate against measurement, compound 4: 5.0-fold (0.70 log units) above; measured number below the stated range.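

In this assay, replacing a 3-methylbut-2-en-1-yl group on this aromatic carbon with hydrogen gives an at least 3.3-fold lower number from compound 3 to compound 4 (0.52 log units; beyond the scatter), so compound 4 is the stronger inhibitor. Within the data shown here, this is the first sign that this position matters: with hydrogen there, the compound returns a measured number. The full size of the step stays unknown because the value of compound 3 is a limit, not a number: the limit of > 100000 nM in this assay, at which 2 of the 4 values shown sit.

From the compounds shown here alone, whether a methyl group, a longer chain or an amine at this position would also give a measured number remains open. So does the part played by the 3-methylbut-2-en-1-yl group that remains in compound 4.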